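Adding a Methyl Group to the Stronger Modulator

A few compounds are considered here, and "the series" means these few. Any claim that something is new, unique, unknown or untested is made for them only; others in the source may bear on it.

Measured compounds:
- compound 1 `Cc1c(-c2cc(-c3ccccc3)no2)cnn1C1CCNCC1`: 1200 nM
- compound 2 `Fc1cccc(Cl)c1-c1cc(-c2cnn(C3CCNCC3)c2)on1`: 48 nM

In an assay on isolated protein for positive allosteric modulation of Neuronal acetylcholine receptor; alpha4/beta2 (Homo sapiens) (on this read-out higher numbers stand for an effect only at larger amounts of compound and lower numbers for an effect already at smaller amounts), compound 2 gives 48 nM, the lowest number of the two measured compounds. Compound 1, which carries an unsubstituted phenyl ring and a methyl group on its five-membered ring, gives 1200 nM in this assay, a gap well beyond the usual scatter. Compound 1 and compound 2 differ in two places at once, so the share of the methyl group in that gap cannot be read off.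

Compound 3 `Cc1c(-c2cc(-c3c(F)cccc3Cl)no2)cnn1C1CCNCC1` is compound 2 with one change: methyl in place of hydrogen on an aromatic carbon. Among the compounds with values here, no directly comparable pair for this change has been measured here. The change is small, and the step from compound 2 to compound 3 is expected to be modest, if any, most likely within the scatter, with a slight lean toward a higher number: a 1.5-fold higher number from compound 2 to compound 3 (0.16 log units; within the scatter). Compound 3 is therefore estimated at 70 nM, in a range from 25 nM to 250 nM.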

Compound 3, half-maximal effective concentration: 6 nM
The estimate for compound 3 lay 12-fold (1.07 log units) above the measured number, and the stated range ends above it.
By their numbers in this assay, from the lowest: compound 3; then compound 2; then compound 1.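

On the five-membered aromatic ring with 2 nitrogen, the carbon next to the ring atom that bears the piperidin-4-yl group proves sensitive to a single added carbon: in this assay, methyl in place of hydrogen gives an 8.0-fold lower number from compound 2 to compound 3 (0.90 log units; beyond the scatter), a step beyond the scatter. With the methyl group held in place, 2-chloro-6-fluorophenyl in place of phenyl gives a 200-fold lower number from compound 1 to compound 3 (2.30 log units; beyond the scatter), a larger step, so the two-place gap between compound 1 and compound 2 now has a one-place counterpart for the ring change. No measurement at hand says why this carbon responds in this way.

Still open, going by these compounds, is whether an ethyl group, a methoxy group or an aminomethyl group at this carbon would go further or lose the gain. Also open is the size of the methyl step with the unsubstituted phenyl ring, as compound 1 has no partner lacking the methyl group among the compounds shown.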